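The source may hold more compounds than are shown below. What is called first, only, known or untested is meant among the compounds shown, and "the series" means these compounds.

Measured so far:

Compound 1, `C=CCn1c(=O)/c(=C\c2cccc(Cl)c2)[nH]c(=O)/c1=C\c1ccccc1OC` — in a functional assay on NCI-H1975 cells (Homo sapiens) for cytotoxicity, read by CCK-8 assay, with a stated time of 72 h (a lower number here means a stronger inhibitor, a higher number a weaker inhibitor), compound 1 gives 5100 nM.
Compound 2, `C=CCn1c(=O)/c(=C\c2ccc(F)c(Br)c2)[nH]c(=O)/c1=C\c1ccccc1OC` — in this assay compound 2 gives "not active" (no number reported).

Compound 2 stands apart from compound 1 in that it carries no single number: the assay reported it only as showing no activity, so its place on the scale cannot be fixed, and nothing can be said about the size of any gap between compound 2 and compound 1 beyond the fact that compound 1 gave a number and compound 2 did not.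

Compound 3, `C=CCn1c(=O)/c(=C\c2cccc(C)c2)[nH]c(=O)/c1=C\c1ccccc1OC`, has not yet been measured. It differs from compound 2 in one place: 3-methylphenyl in place of 3-bromo-4-fluorophenyl on a double-bonded chain carbon bound to an aromatic carbon. The nearest guide is compound 1, which also carries a single small substituent on that same phenyl ring and gave 5100 nM. Among the compounds with values here, since compound 2 gave no number, no step from compound 2 can be sized; the expectation is instead that compound 3 comes out in the region of compound 1, with a real chance that the assay again reports no activity rather than a value.

The estimate for compound 3 in this assay is 8000 nM, within a range from 2500 nM to 30000 nM.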

Compound 3, half-maximal inhibitory concentration: 32800 nM
Beside the measured number, compound 3's estimate is 4.1-fold (0.61 log units) below it; the whole stated range lies below it.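

In this assay, putting methyl in place of chloro on an aromatic carbon gives a 6.4-fold higher number from compound 1 to compound 3 (0.81 log units; beyond the scatter), a step beyond the usual scatter, so this phenyl substituent clearly affects the reading and the two small groups are not interchangeable here. Compound 2, with 3-bromo-4-fluorophenyl, was reported as not active, while compound 3, with 3-methylphenyl, gives a number, but the step between them cannot be read and no size can be put on it. Nothing available explains why the methyl compound is the weaker of the pair.

Within the data shown here, with only one readable step, no general ranking of substituents at this place can be drawn, and it remains open whether a nitrile, a trifluoromethyl group or an amine on this ring would read closer to compound 1 or to compound 3. Going by these compounds, it is also open whether the chloro-to-methyl step would keep its size if another part of the shared core were changed.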